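A few compounds are considered here, and "the series" means these few. Any claim that something is new, unique, unknown or untested is made for them only; others in the source may bear on it.

Measured compounds:
Compound 1, `COC(=O)c1cc(-c2cccc(NC(=O)c3ccc(/C=C/C(=O)c4cccc([N+](=O)[O-])c4)cc3)c2)on1`, in an ADME assay on Vero cells (Chlorocebus sabaeus) for cytotoxicity, read by MTT assay, with a stated time of 72 h (on this read-out lower numbers stand for higher toxicity in this test and higher numbers for lower toxicity in this test), gives > 40 ug/mL, a limit of the assay.
Compound 2, `COC(=O)c1cc(-c2cccc(NC(=O)c3ccc(/C=C/C(=O)c4ccc(OC)cc4OC)cc3)c2)on1`, in this assay gives > 50 ug/mL, a limit.
Compound 3, `COC(=O)c1cc(-c2cccc(NC(=O)c3ccc(/C=C/C(=O)c4ccc(Cl)cc4)cc3)c2)on1`, in this assay gives > 50 ug/mL, a limit.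

Compound 3 thus stands at a limit in this assay, not at a number. The other two values shown are limits as well: the limit of > 50 ug/mL in this assay, at which 2 of the 3 values shown sit, and (the limit of > 40 ug/mL in this assay, at which 1 of the 3 values shown sits). The steps among the measured compounds, a step that the two limits leave unreadable from compound 1 to compound 3, a step that the two limits leave unreadable from compound 2 to compound 3 and a step that the two limits leave unreadable from compound 1 to compound 2, carry no readable size, so none of them gives a usable size for the change to compound 4.

Compound 4, `COC(=O)c1cc(-c2cccc(NC(=O)c3ccc(/C=C/C(=O)c4ccc([N+](=O)[O-])cc4)cc3)c2)on1`, differs from compound 3 by nitro in place of chloro on an aromatic carbon. Compound 1 also carries a 3-nitrophenyl on a carbonyl carbon, and its value in this assay is a limit. Among the measured compounds shown here, no measured step gives a direction or size for this change; the expectation is that compound 4 also reaches a limit in this assay, with no step beyond the scatter. Compound 4 is expected at 60 ug/mL, from 40 ug/mL to 100 ug/mL. The expected step that the limit leaves unreadable from compound 3 to compound 4 means no change beyond the scatter.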

Compound 4, half-maximal cytotoxic concentration: > 20 ug/mL
Compound 4 gave a limit, no number; the forecaster's own chance of this, stated with the estimate: 85%; the middle value lies beyond the limit too.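

Compound 4 gives > 20 ug/mL in this assay, a limit and not a number, and compounds 1, 2 and 3 also stand at limits, so none of its steps to them can be read. The compounds shown leave open whether nitro in place of chloro changes the half-maximal cytotoxic concentration at all.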